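The source may report more compounds than this note shows. Statements on the series, on what has been measured and on what is new or still open speak of the compounds shown alone.

Measured so far in a functional assay on Bel7402/5-FU cells (Homo sapiens) for antiproliferative activity, read by MTT assay, with a stated time of 72 h; on this read-out lower numbers stand for stronger inhibition and higher numbers for weaker inhibition:
- compound 1 `C=C1C(=O)O[C@H]2[C@H]1CC/C(Cn1cc(Cn3cc(F)c(=O)[nH]c3=O)nn1)=C\CC[C@@]1(C)O[C@@H]21` gives > 20000 nM.
- compound 2 `C=C1C(=O)O[C@H]2[C@H]1CC/C(COC(=O)CCC(=O)N1CCN(C(=O)Cn3cc(F)c(=O)[nH]c3=O)CC1)=C\CC[C@@]1(C)O[C@@H]21` gives > 20000 nM.
- compound 3 `C=C1C(=O)O[C@H]2[C@H]1CC/C(COC(=O)Cn1cc(F)c(=O)n(Cc3ccccc3)c1=O)=C\CC[C@@]1(C)O[C@@H]21` gives 4270 nM.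

For compound 1 the entry in this assay is a limit of the assay, not a number. For compound 2 the entry is likewise a limit. Two of the three values sit at the limit of > 20000 nM in this assay, at which 2 of the 3 values shown sit. Among the measured compounds shown here, compound 3 thus holds the only measured number in the set, and no step between measured compounds can be computed from it.

Compound 4 `C=C1C(=O)O[C@H]2[C@H]1CC/C(COC(=O)Cn1cc(F)c(=O)n(Cc3cc(F)ccc3F)c1=O)=C\CC[C@@]1(C)O[C@@H]21` has not been measured. It differs from compound 3 by 2,5-difluorophenyl in place of phenyl on a saturated chain carbon bound to an aromatic nitrogen. For the measured compounds named here, with only one number to lean on, the step of a 1.2-fold lower number from compound 3 to compound 4 (0.09 log units; within the scatter) is expected to stay within the usual scatter, with no direction claimed. Compound 4 is expected at 3500 nM, with a range from 1500 nM to 9000 nM.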

Compound 4, half-maximal inhibitory concentration: 4610 nM
The estimate for compound 4 lay 1.3-fold (0.12 log units) below the measured number; measured number inside the range.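

Among the compounds shown here, the step of a 1.1-fold higher number from compound 3 to compound 4 (0.03 log units; within the scatter) is the first that can be read: in this assay, 2,5-difluorophenyl and phenyl on a saturated chain carbon bound to an aromatic nitrogen cannot be told apart. This position therefore accepts the change from benzyl to 2,5-difluorobenzyl with no reading beyond the scatter. Nothing at hand explains this result.

Open, as far as these compounds go, is whether an amine or a carboxylic acid on the benzyl group, or a longer chain in its place, would shift the number beyond the scatter. No pair shown isolates the contribution of the benzyl group itself.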